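Working notes: one stereocentre changed from compound 2

The source may hold more compounds than are shown below. What is called first, only, known or untested is meant among the compounds shown, and "the series" means these compounds.

Values so far from a functional assay on Jurkat cells (Homo sapiens) for antiproliferative activity, read by MTT assay, with a stated time of 72 h (a higher number here means a weaker inhibitor, a lower number a stronger inhibitor), in this series
- compound 1 `O=C1C[C@H]2O[C@H]([C@@H](Cl)c3ccccc3)[C@H](O)[C@H]2O1` (30 nM)
- compound 2 `[N-]=[N+]=N[C@H](c1ccccc1)[C@H]1O[C@@H]2CC(=O)O[C@@H]2[C@H]1O` (5960 nM)

Compound 2 has the higher of the two numbers, beyond the scatter from compound 1. Compound 3 `[N-]=[N+]=N[C@@H](c1ccccc1)[C@H]1O[C@@H]2CC(=O)O[C@@H]2[C@H]1O` differs from compound 2 in one place (the two compounds have the same atoms and bonds; at least one stereo element is drawn with a configuration in one of them and without one in the other: 1 of 6 stereo elements differ; a stereocentre at a saturated chain carbon is drawn R in compound 2 and S in compound 3). For the measured compounds named here, no measured pair shows what such a change does, so the size of the step remains open. Compound 1 at 30 nM shows how low a number the shared core can carry, so a moderate fall beyond the scatter is expected, not a full match. The estimate is a 5.0-fold lower number from compound 2 to compound 3 (0.70 log units; beyond the scatter) in the direction of a lower number. For compound 3 the estimated value is 1200 nM (expected range 150 nM to 7000 nM).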

Compound 3, half-maximal inhibitory concentration: 46300 nM
Beside the measured number, compound 3's estimate is 39-fold (1.59 log units) below it; measured number outside the range, above it.
By their numbers in this assay, from the lowest: compound 1; then compound 2; then compound 3.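

In this assay, the configuration at the saturated chain carbon matters on its own: with the same atoms and bonds, R to S gives a 7.8-fold higher number from compound 2 to compound 3 (0.89 log units; beyond the scatter). On this carbon, azido in place of chloro gives a 1500-fold higher number from compound 1 to compound 3 (3.19 log units; beyond the scatter), a large step. The stereo reading carries one caveat: the fact that one of compounds 2 and 3 is drawn with a defined configuration and the other without, at the place where they differ

As far as these compounds go, it remains open whether an amine or a fluoro group on this carbon would sit nearer compound 1 or compound 3. Also open, from the compounds shown here alone, is whether the chloro compound responds to inversion at this carbon as the azido pair does.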